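Inverting Both Stereocentres: From Compound 3 to Compound 4

This account rests on a few compounds, and the source may have more. Where it says the series, first, only, none or still open, it means among the compounds named here.

Measured so far:
compound 1, `CC(=O)O[C@H](CCc1ccc(O)cc1)C[C@H](O)CCc1ccc(O)cc1`, with 32000 nM in a functional assay on RAW264.7 cells (Mus musculus) for inhibition, read by spectrophotometry and Griess assay, with a stated time of 24 h; a lower number here means a stronger inhibitor, a higher number a weaker inhibitor
compound 2, `CC(=O)O[C@H](CCc1ccc(O)c(O)c1)C[C@H](O)CCc1ccc(O)c(O)c1`, with 35500 nM
compound 3, `CC(=O)O[C@@H](CCc1ccc(O)c(O)c1)C[C@@H](O)CCc1ccc(O)cc1`, with 9520 nM

Compound 3 gives the lowest number of the three. Both compound 1 and compound 2 lie higher by more than the usual scatter, so compound 3 is the strongest inhibitor seen here. Compound 4, `CC(=O)O[C@H](CCc1ccc(O)c(O)c1)C[C@H](O)CCc1ccc(O)cc1`, has not yet been measured. It is the mirror image of compound 3: the two compounds have the same atoms and bonds and differ only in configuration as drawn: 2 of 2 stereo elements differ (all stereocentres are inverted: mirror images); a stereocentre at a saturated chain carbon is drawn S in compound 3 and R in compound 4; a stereocentre at a saturated chain carbon is drawn S in compound 3 and R in compound 4. Within the data shown here, no measured pair shows what such an inversion does in this assay, so the direction rests on general experience that the two mirror forms of a compound often differ in a cell. A modest weakening is expected, a step of a 1.7-fold higher number from compound 3 to compound 4 (0.23 log units; within the scatter). Compound 4 is therefore estimated at 16000 nM, within a range from 5000 nM to 50000 nM.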

Compound 4, half-maximal inhibitory concentration: 9520 nM
Beside the measured number, compound 4's estimate is 1.7-fold (0.23 log units) above it; the measured number falls inside the stated range.
By their numbers in this assay, from the lowest: compounds 3 and 4 (each within the scatter of the next); then compounds 1 and 2 (each within the scatter of the next).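

In this assay, among these compounds, inverting both stereocentres gives no change at the digits printed from compound 3 to compound 4 (within the scatter), the first mirror pair here, and its reading rests on one fact: the fact that compounds 3 and 4 differ only in the configuration as drawn. Compound 4 also shares its drawn configuration with compound 1 and compound 2, so hydroxy changes on the rings can now be read alone. Hydrogen in place of hydroxy on an aromatic carbon gives a 3.7-fold lower number from compound 2 to compound 4 (0.57 log units; beyond the scatter), while hydroxy in place of hydrogen on an aromatic carbon gives a 3.4-fold lower number from compound 1 to compound 4 (0.53 log units; beyond the scatter), so both single changes lead to a lower number.

From the compounds shown here alone, it remains open how an amine or a carboxylic acid on the rings would read in this assay. Going by these compounds, a longer chain in the core is equally open.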